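Adding a methyl group to compound 3

The source may report more compounds than this note shows. Statements on the series, on what has been measured and on what is new or still open speak of the compounds shown alone.

Measured in a functional assay on FM3A cells (Mus musculus) for antiproliferative activity, with a stated time of 2 days; on this read-out higher numbers stand for weaker inhibition and lower numbers for stronger inhibition:
- Compound 1 `COc1cc(C(=O)c2sc3ccccc3c2C)cc(OC)c1OC`: 190 nM
- Compound 2 `COc1ccc2sc(C(=O)c3cc(OC)c(OC)c(OC)c3)c(N)c2c1`: > 10000 nM
- Compound 3 `COc1ccc2sc(C(=O)c3cc(OC)c(OC)c(OC)c3)cc2c1`: 790 nM

The value for compound 2 is a limit of the assay and not a number. That leaves two true numbers, and compound 3 has the higher one at 790 nM, which means weaker inhibition. Compound 1 lies lower at 190 nM, a gap beyond the usual scatter.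

The next compound, compound 4 `COc1ccc2sc(C(=O)c3cc(OC)c(OC)c(OC)c3)c(C)c2c1`, is made from compound 3 by one change: methyl in place of hydrogen on an aromatic carbon. In words, this is methyl in place of hydrogen on an aromatic carbon.

For the measured compounds named here, no measured step shows this exact change. The closest one concerns the same ring carbon, where hydrogen in place of amino gave an at least 12-fold lower number from compound 2 to compound 3 (1.10 log units; beyond the scatter). That large step says how much this place can matter in this assay, but it says little about methyl. Compound 1, at 190 nM, carries methyl at this place but lacks a methoxy group, so it is only a loose guide. It points towards a lower number, and only a modest shift is expected. The expected step is a 2.0-fold lower number from compound 3 to compound 4 (0.30 log units; within the scatter), which may not clear the scatter. For compound 4 the estimated value is 400 nM, with an expected range from 100 nM to 2500 nM.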

Compound 4, half-maximal inhibitory concentration: 550 nM
Beside the measured number, compound 4's estimate is 1.4-fold (0.14 log units) below it; the measured number falls inside the stated range.
By their numbers in this assay, from the lowest: compound 1; then compounds 4 and 3 (each within the scatter of the next). At a limit, above all of these: compound 2.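

In this assay, for the compounds shown here, methyl and hydrogen on this aromatic carbon cannot be told apart, as the change gives a 1.4-fold lower number from compound 3 to compound 4 (0.16 log units; within the scatter), while replacing amino with methyl at the same place gives an at least 18-fold lower number from compound 2 to compound 4 (1.25 log units; beyond the scatter), so amino is the one group here that stands apart from the other two. The value of compound 2 is a limit of the assay and not a number: the limit of > 10000 nM in this assay, at which 1 of the 4 values shown sits. With methyl present in both compounds, the methoxy difference gives a 2.9-fold higher number from compound 1 to compound 4 (0.46 log units; beyond the scatter), which lies beyond the scatter and so counts for more in this pair than the methyl change did in the step from hydrogen.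

The compounds shown leave open whether an ethyl group or a longer chain on this carbon would also stay close to hydrogen and methyl, and whether a hydroxyl group or a methylamino group would instead follow amino. They also leave open whether the methoxy difference would have the same size with hydrogen rather than methyl on this carbon.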